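Pyridin-4-yl in place of 4-fluorophenyl on compound 2

The compounds below may be only part of what the source reports. "The series", "measured", "known", "first", "only" and "open" are said of these compounds alone.

In a functional assay on MDA-MB-231 cells (Homo sapiens) for antiproliferative activity, with a stated time of 4 days (on this read-out lower numbers stand for stronger inhibition and higher numbers for weaker inhibition), compound 1 (`COc1ccc(-c2[nH]c3ccc(C)cc3c2C=O)cc1`) gives 86 nM and compound 2 (`CCCCc1ccc2[nH]c(-c3ccc(OC)cc3)c(/C=N/NC(=O)c3ccc(F)cc3)c2c1`) gives 19 nM as the lower of the two numbers, a gap beyond the scatter. These two compounds differ in more than one place, and their gap assigns nothing to any single group. Compound 3 (`CCCCc1ccc2[nH]c(-c3ccc(OC)cc3)c(/C=N/NC(=O)c3ccncc3)c2c1`) carries pyridin-4-yl in place of 4-fluorophenyl on a carbonyl carbon and is otherwise the same as compound 2. Among the measured compounds shown here, no measured step covers this exchange, and the expectation rests only on compound 2 at 19 nM and on the structural change. In this assay the expected result is a small weakening, close to the scatter, with the estimated 1.8-fold higher number from compound 2 to compound 3 (0.27 log units; within the scatter) as its size. Compound 3 is estimated at 35 nM (expected range 12 nM to 100 nM).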

Compound 3, half-maximal inhibitory concentration: 29 nM
The estimate for compound 3 lay 1.2-fold (0.08 log units) above the measured number; measured number inside the range.
By their numbers in this assay, from the lowest: compounds 2 and 3 (each within the scatter of the next); then compound 1.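

In this assay pyridin-4-yl in place of 4-fluorophenyl on a carbonyl carbon gives a 1.5-fold higher number from compound 2 to compound 3 (0.18 log units; within the scatter) and is the only single-place step shown, so the two groups cannot be told apart on this read-out. At this position, a six-membered aromatic ring with one hetero atom and one hydrogen-bond acceptor can stand in for a ring of carbon only without a change beyond the scatter. No measurement at hand bears on the reason for this result.

Going by these compounds, whether the position also tolerates a saturated amine such as piperidin-4-yl, or a carboxylic acid on the ring, remains open. Among the compounds shown here, the step covers only this group on the carbonyl carbon, so the share of the butyl chain in the number for compound 2 cannot be read.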